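The source may report more compounds than this note shows. Statements on the series, on what has been measured and on what is new or still open speak of the compounds shown alone.

Compound 1, `CN1CCN(c2ccc(Nc3ncc4nc(Nc5ccc(F)cc5)n([C@H]5CCCN(S(=O)(=O)C6CC6)C5)c4n3)cc2)CC1`, was tested in a functional assay on A549 cells (Homo sapiens) for antiproliferative activity, read by MTT assay, with a stated time of 72 h; a lower number here means a stronger inhibitor, a higher number a weaker inhibitor. In this assay compound 1 gives 1320 nM, the lower of the two numbers obtained. Compound 3, `CN1CCN(c2ccc(Nc3ncc4nc(Nc5ccccc5)n([C@@H]5CCN(S(=O)(=O)C6CC6)C5)c4n3)cc2)CC1`, gives 2910 nM in this assay, and the gap between these two numbers lies beyond the usual scatter of repeated measurements. Compound 2, `CN1CCN(c2ccc(Nc3ncc4nc(Nc5ccc(F)cc5)n([C@H]5CCCC(NC(=O)OC(C)(C)C)C5)c4n3)cc2)CC1`, was also part of the study, but in this assay compound 2 is recorded as "not determined" (no result reported), so no number stands for it.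

Compound 4, `CN1CCN(c2ccc(Nc3ncc4nc(Nc5ccc(F)cc5)n([C@H]5CCCN(C(=O)CO)C5)c4n3)cc2)CC1`, differs from compound 1 in a single place: (hydroxymethyl)carbonyl in place of cyclopropylsulfonyl on an amine nitrogen in a ring. The cyclopropylsulfonyl group, with its three-membered ring, leaves; the (hydroxymethyl)carbonyl group, which carries one hydrogen-bond donor, enters on the amine nitrogen in the six-membered ring.

Within the data shown here, no pair of measured compounds shows this change, so there is no measured step to lean on. Compound 3 differs from compound 1 in more than one place, so its number says nothing about the ring nitrogen substituent on its own. Without a comparable step, the expectation for the step of a 1.4-fold higher number from compound 1 to compound 4 (0.13 log units; within the scatter) is one that stays within the scatter, or at most a modest move toward a weaker inhibitor. Compound 4 is therefore expected to give about 1800 nM in this assay, with a range from 700 nM to 4500 nM.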

Compound 4, half-maximal inhibitory concentration: 830 nM
Beside the measured number, compound 4's estimate is 2.2-fold (0.34 log units) above it; measured number inside the range.
By their numbers in this assay, from the lowest: compounds 4 and 1 (each within the scatter of the next); then compound 3.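

Among these compounds, the step of a 1.6-fold lower number from compound 1 to compound 4 (0.20 log units; within the scatter) in this assay is the first direct look at this position, and by this measure compound 1 and compound 4 cannot be told apart. On the amine nitrogen of the six-membered ring, then, the (hydroxymethyl)carbonyl group, with no ring, fewer heavy atoms and one hydrogen-bond donor, serves as well as cyclopropylsulfonyl, so neither the three-membered ring nor the sulfur is needed to hold the number in this pair. No measurement is available that would explain this result.

A single step cannot show how much variation this position accepts: an amine or a carboxylic acid in place of the hydroxyl group, or a longer chain on the carbonyl, could stay at the level of compound 4 or move well away from it. On these data alone, it also remains open whether the same exchange would give a similar result on compound 3, which differs from compound 1 in more than one place.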